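The source may hold more compounds than are shown below. What is called first, only, known or untested is meant among the compounds shown, and "the series" means these compounds.

In an ADME assay on Vero cells (Chlorocebus sabaeus) for cytotoxicity, read by MTT assay, with a stated time of 72 h (on this read-out higher numbers stand for lower toxicity in this test and lower numbers for higher toxicity in this test), three analogues sharing one core have been measured. Compound 1 `N/C(=N/NC(CC(=O)c1ccc(-n2ccnc2)cc1)c1ccccc1Cl)c1ccccn1` gives 53200 nM. Compound 2 `N/C(=N/NC(CC(=O)c1ccc(-n2ccnc2)cc1)c1cccc(F)c1)c1ccccn1` gives 26500 nM, and compound 3 `N/C(=N/NC(CC(=O)c1ccc(-n2ccnc2)cc1)c1ccc(Cl)cc1Cl)c1ccccn1` gives 27800 nM. Compound 3 stands close to compound 2, a gap of a 1.0-fold higher number from compound 2 to compound 3 (0.02 log units; within the scatter), and its gap to compound 1, a 1.9-fold lower number from compound 1 to compound 3 (0.28 log units; within the scatter), is also within the scatter, so the three numbers cannot be told apart.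

Compound 4 `N/C(=N/NC(CC(=O)c1ccc(-n2ccnc2)cc1)c1cccc(Cl)c1)c1ccccn1` differs from compound 3 in one place: 3-chlorophenyl in place of 2,4-dichlorophenyl on a saturated chain carbon bound to an amine nitrogen and a saturated chain carbon. Among the measured compounds shown here, two measured steps bear on exchanges of the aryl group at this carbon. The step of a 2.0-fold lower number from compound 1 to compound 2 (0.30 log units; within the scatter) and the step of a 1.0-fold higher number from compound 2 to compound 3 (0.02 log units; within the scatter) both stayed within the scatter, and the step of a 1.9-fold lower number from compound 1 to compound 3 (0.28 log units; within the scatter) did likewise. No exchange of this aryl group has so far moved this assay beyond its scatter, so compound 4 is expected to show a step of a 1.1-fold higher number from compound 3 to compound 4 (0.03 log units; within the scatter), with no change beyond the scatter. Compound 4 is therefore estimated at 30000 nM, within a range from 14000 nM to 65000 nM.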

Compound 4, half-maximal cytotoxic concentration: 68600 nM
Beside the measured number, compound 4's estimate is 2.3-fold (0.36 log units) below it, outside the stated range (above it).
By their numbers in this assay, from the lowest: compounds 2, 3, 1 and 4 (each within the scatter of the next, the first and the last beyond it).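

In this assay, the aryl group on the saturated chain carbon bound to an amine nitrogen and a saturated chain carbon has now moved the number beyond the scatter: there is a 2.5-fold higher number from compound 3 to compound 4 (0.39 log units; beyond the scatter) for the exchange of 2,4-dichlorophenyl for 3-chlorophenyl and a 2.6-fold higher number from compound 2 to compound 4 (0.41 log units; beyond the scatter) for chloro in place of fluoro on an aromatic carbon. Both steps are modest, and a 1.3-fold higher number from compound 1 to compound 4 (0.11 log units; within the scatter) leaves 3-chlorophenyl indistinguishable from the 2-chlorophenyl of compound 1, so the shift holds only against compound 2 and compound 3. Nothing available here accounts for these differences.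

The compounds shown leave open how this assay responds when a methoxy group or an amine takes the place of the chloro on the aromatic carbon. They also leave open whether an unsubstituted phenyl at this carbon would stand with compound 4 or with compound 2.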